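The source may hold more compounds than are shown below. What is called first, only, known or untested is meant among the compounds shown, and "the series" means these compounds.

Compound 1 `CC(Sc1nnc(-c2ccncc2)s1)C(=O)Nc1ccccc1Cl`: in an ADME assay on BHK-21 cells (Mesocricetus auratus) for cytotoxicity, with a stated time of 3 days (on this read-out higher numbers stand for lower toxicity in this test and lower numbers for higher toxicity in this test), compound 1 gives only a limit of > 50000 nM.
Compound 2 `CC(Sc1nnc(-c2ccncc2)s1)C(=O)Nc1c(Cl)cccc1Cl`: in this assay compound 2 gives only a limit of > 50000 nM.

Going by the values given here, compound 1 therefore stands at a limit rather than at a number, and the one further value shown is a limit as well. Among the compounds with values here, the single measured step, a step that the two limits leave unreadable from compound 1 to compound 2, cannot be read for size, as both values sit at the limit described in the limit of > 50000 nM in this assay, at which 2 of the 2 values shown sit. Compound 3 `O=C(CSc1nnc(-c2ccncc2)s1)Nc1ccccc1Cl` differs from compound 1 by hydrogen in place of methyl on a saturated chain carbon bound to a carbonyl carbon and a sulfur. Within the data shown here, no measured step involves this kind of change, and the only step available is unreadable, so nothing in the data points to a shift in either direction. Compound 3 is expected to remain at the limit, with the step that the limit leaves unreadable from compound 1 to compound 3 estimated as none beyond the scatter. The estimate for compound 3 is 60000 nM, in a range from 20000 nM to 200000 nM.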

Compound 3, half-maximal cytotoxic concentration: > 50000 nM
Compound 3 was reported as a limit (the forecaster's own chance of this, stated with the estimate: 75%); the middle value is on the limit's open side.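

No step between compound 1, compound 2 and compound 3 can be read, since all three stand at the same limit: the limit of > 50000 nM in this assay, at which 3 of the 3 values shown sit.

What the compounds shown leave open is how far any of these changes moves the cytotoxic concentration in this assay, since none gives a number.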